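A few compounds are considered here, and "the series" means these few. Any claim that something is new, unique, unknown or untested is made for them only; others in the source may bear on it.

Three compounds have a reading so far in a functional assay on Hs 683 cells (Homo sapiens) for cytotoxicity, read by MTT assay, with a stated time of 72 h; a higher number here means a weaker inhibitor, a lower number a stronger inhibitor. Compound 1 `c1ccc2[nH]c(-n3cccn3)cc2c1` gives > 100000 nM, which is a limit of the assay and not a number. Compound 2 `COc1ccc2[nH]c(-c3ccc[nH]3)cc2c1` gives 50000 nM. Compound 3 `COc1ccc2[nH]c3c(c4c(c5ccnn53)C(=O)NC4=O)c2c1` gives 22000 nM, the lower of the two actual numbers, and its modest gap to compound 2 lies beyond the usual scatter of repeat measurements.

Compound 4 `Cc1ccc2[nH]c3c(c4c(c5ccnn53)C(=O)NC4=O)c2c1` has not yet been measured. It keeps the core of compound 3 and differs in one place, with methyl in place of methoxy on an aromatic carbon. For the measured compounds named here, no measured pair shows what this swap does in this assay, so the expectation starts from compound 3 at 22000 nM. The change is a single small group on a large shared core, so no shift beyond the scatter is expected, and no direction can be favoured. The estimated size of the change is a 1.1-fold higher number from compound 3 to compound 4 (0.06 log units; within the scatter). The expected value for compound 4 is 25000 nM, with an estimated range from 9000 nM to 70000 nM.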

Compound 4, half-maximal inhibitory concentration: 64000 nM
Compound 4: middle estimate off by 2.6-fold (0.41 log units), on the low side, within the range that was stated.
By their numbers in this assay, from the lowest: compound 3; then compounds 2 and 4 (each within the scatter of the next). At a limit, above all of these: compound 1.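

For the compounds shown here, compound 3 and compound 4 form the only pair here that differs in one place, and in this assay replacing methoxy with methyl gives a 2.9-fold higher number from compound 3 to compound 4 (0.46 log units; beyond the scatter), so the shared core does respond to a change at this aromatic carbon. The step is modest, but it shows that methoxy gives the stronger inhibitor of these two, although this single pair cannot say whether the hydrogen-bond acceptor lost with methoxy is what matters. Compound 1 stands at a limit, which is not a number, and that limit marks the top of the readable range: the limit of > 100000 nM in this assay, at which 1 of the 4 values shown sits.

From the compounds shown here alone, it remains open whether an amine or a hydroxyl group on this carbon would lower the number further. Going by these compounds, it is also open whether the same swap would have a similar effect on another core.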